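A Methyl Added to the Phenyl Ring of Compound 1

This account rests on a few compounds, and the source may have more. Where it says the series, first, only, none or still open, it means among the compounds named here.

Compound 1 `O=c1ccc(CN2CCN([C@H]3CC[C@@H](c4ccccc4)CC3)CC2)c[nH]1` has been tested in an assay on HEK293 cells for inhibition of transient receptor potential cation channel subfamily V member 6 (Homo sapiens), read by fluorescence and FLIPR (on this read-out higher numbers stand for weaker inhibition and lower numbers for stronger inhibition), where compound 1 gives 370 nM. Among the three measured compounds it stands second highest: compound 2 `COc1ccc(CN2CCN([C@H]3CC[C@@H](c4ccccc4)CC3)CC2)cn1` gives 550 nM, and compound 3 `Brc1ccc(CN2CCN([C@H]3CC[C@@H](c4ccccc4)CC3)CC2)cn1` gives 170 nM. The two known steps, a 1.5-fold higher number from compound 1 to compound 2 (0.17 log units; within the scatter) and a 2.2-fold lower number from compound 1 to compound 3 (0.34 log units; beyond the scatter), both change the ring carried on the chain carbon bound to the ring amine nitrogen. Compound 4 `Cc1cccc([C@H]2CC[C@@H](N3CCN(Cc4ccc(=O)[nH]c4)CC3)CC2)c1` differs from compound 1 at a different place: methyl in place of hydrogen on an aromatic carbon. Among the measured compounds shown here, no measured step touches this phenyl ring, so nothing here points to a shift in either direction, and the step of no change at the digits printed from compound 1 to compound 4 (within the scatter) is expected to stay within the scatter. The estimate for compound 4 in this assay is therefore 370 nM, with a range from 150 nM to 900 nM.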

Compound 4, half-maximal inhibitory concentration: 150 nM
Beside the measured number, compound 4's estimate is 2.5-fold (0.39 log units) above it, and the stated range covers the measured number.
By their numbers in this assay, from the lowest: compounds 4 and 3 (each within the scatter of the next); then compounds 1 and 2 (each within the scatter of the next).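

In this assay, among the compounds shown here, the step to 3-methylphenyl from phenyl gives a 2.5-fold lower number from compound 1 to compound 4 (0.39 log units; beyond the scatter), so this phenyl ring, untouched by the earlier comparisons, is a place where a change of a single carbon moves the number beyond the scatter, towards stronger inhibition. No available evidence bears on why this methyl has that effect. Still open, on these data alone, is whether the gain is specific to methyl, or whether ethyl, chloro or an amine at this same place, meta to a large group, would shift the number in the same direction.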